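This account rests on a few compounds, and the source may have more. Where it says the series, first, only, none or still open, it means among the compounds named here.

Compound 1 `COc1ccc(S(=O)(=O)N2CCc3cccc(-c4cccnc4)c32)cc1`: 95.9 nM
Compound 2 `COc1ccc(S(=O)(=O)N2CCc3cccc(-c4ccc(C#N)cc4)c32)cc1`: 31.1 nM
Compound 3 `COc1ccc(S(=O)(=O)N2CCc3cccc(-c4ccncc4)c32)cc1`: 96 nM

Of the compounds shown here, three sharing one core have been tested in a functional assay on KB cells (Homo sapiens) for inhibition, with a stated time of 72 h (on this read-out lower numbers stand for stronger inhibition and higher numbers for weaker inhibition), and they differ only in the aromatic group on the core. Compound 3 stands at the highest number of the three, though compound 1 sits at the same place: a 1.0-fold higher number from compound 1 to compound 3 (0.00 log units; within the scatter). Compound 2 is set apart from both, as a 3.1-fold higher number from compound 2 to compound 3 (0.49 log units; beyond the scatter) and a 3.1-fold lower number from compound 1 to compound 2 (0.49 log units; beyond the scatter) show.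

Compound 4 `COc1ccc(S(=O)(=O)N2CCc3cccc(-c4cccs4)c32)cc1` is not yet measured. Compared with compound 3, the change is thiophen-2-yl in place of pyridin-4-yl on an aromatic carbon. Going by the values given here, none of the measured steps swaps a six-membered ring for a five-membered one; the only steps on record either leave the number unchanged, as from compound 1 to compound 3, or move it by a modest amount, as from compound 3 to compound 2. On that basis a step in this assay that is small, at most modest and more likely toward a lower number, is expected, namely a 1.4-fold lower number from compound 3 to compound 4 (0.14 log units; within the scatter). Compound 4 is therefore estimated at 70 nM, with a range from 25 nM to 200 nM.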

Compound 4, half-maximal inhibitory concentration: 215 nM
Estimate against measurement, compound 4: 3.1-fold (0.49 log units) below; the measured number lies above the stated range.
By their numbers in this assay, from the lowest: compound 2; then compounds 1 and 3 (each within the scatter of the next); then compound 4.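

In this assay the aromatic group on the shared core can also move the number upward, since thiophen-2-yl gives a 2.2-fold higher number from compound 3 to compound 4 (0.35 log units; beyond the scatter) and a 2.2-fold higher number from compound 1 to compound 4 (0.35 log units; beyond the scatter), which sets compound 4 apart from the two pyridine compounds that had matched each other. Against the 4-cyanophenyl group the same swap gives a 6.9-fold higher number from compound 2 to compound 4 (0.84 log units; beyond the scatter), so compound 4 now stands at the weak end of the series, beyond the scatter from all three others, and the choice of group on this aromatic carbon spans a wider range than the six-membered rings alone had shown. Nothing measured here accounts for the position of the five-membered ring.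

With thiophen-2-yl the only five-membered ring shown, it remains open whether furan-2-yl or thiophen-3-yl would give a similar number. Going by these compounds, it is also open whether the lower number of compound 2 depends on the nitrile, which a plain phenyl or a 4-carboxyphenyl group would help to test.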